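The source may hold more compounds than are shown below. What is called first, only, known or untested is meant among the compounds shown, and "the series" means these compounds.

Of the compounds shown here, three that share one core have been measured in an assay on microsomes from intestine for inhibition of acyl-CoA:cholesterol acyltransferase (Oryctolagus cuniculus); a higher number here means a weaker inhibitor, a lower number a stronger inhibitor. Compound 1 `CC(C)c1cccc(C(C)C)c1OC(=O)NC(=O)OCc1ccccc1` gives 77 nM in this assay. Compound 2 `CCCCCCOC(=O)NC(=O)Oc1c(C(C)C)cccc1C(C)C` gives 53 nM in this assay, and compound 3 `CCCCCCCCOC(=O)NC(=O)Oc1c(C(C)C)cccc1C(C)C` gives 250 nM in this assay. Compound 3 therefore carries the highest number of the three and is the weakest inhibitor among them: the step of a 3.2-fold higher number from compound 1 to compound 3 (0.51 log units; beyond the scatter) and the step of a 4.7-fold higher number from compound 2 to compound 3 (0.67 log units; beyond the scatter) both lie beyond the scatter, whereas the step of a 1.5-fold lower number from compound 1 to compound 2 (0.16 log units; within the scatter) does not.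

Compound 4 `CC(C)c1cccc(C(C)C)c1OC(=O)NC(=O)SCc1ccc(Cl)cc1` has not yet been measured. It differs from compound 3 by (4-chlorobenzyl)sulfanyl in place of octyloxy on a carbonyl carbon. Among the measured compounds shown here, the measured step that bears most on this change is the one from compound 1 to compound 3, where a phenyl group on the chain gave way to a plain chain and the number rose, the step of a 3.2-fold higher number from compound 1 to compound 3 (0.51 log units; beyond the scatter). Compound 4 restores an aromatic ring to the chain, so the change runs against that step, and a modest move to a lower number is expected in this assay. For the measured compounds named here, the sulfur and the chlorine of compound 4 have no counterpart among the measured compounds, so the size of the move is uncertain. Compound 4 is expected to give about 80 nM in this assay, within a range from 25 nM to 250 nM. The expected step is a 3.1-fold lower number from compound 3 to compound 4 (0.49 log units; beyond the scatter).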

Compound 4, half-maximal inhibitory concentration: 160 nM
Estimate against measurement, compound 4: 2.0-fold (0.30 log units) below; low and high end bracket the measured number.
By their numbers in this assay, from the lowest: compounds 2 and 1 (each within the scatter of the next); then compounds 4 and 3 (each within the scatter of the next).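

In this assay, the step of a 1.6-fold lower number from compound 3 to compound 4 (0.19 log units; within the scatter) lies within the scatter, so on this carbonyl carbon, (4-chlorobenzyl)sulfanyl and octyloxy cannot be told apart, even though one group carries an aromatic ring and the other is a plain chain. The same group does stand apart from the two better-performing groups, with the step of a 3.0-fold higher number from compound 2 to compound 4 (0.48 log units; beyond the scatter) against hexyloxy and the step of a 2.1-fold higher number from compound 1 to compound 4 (0.32 log units; beyond the scatter) against benzyloxy, both beyond the scatter, which shows that an aromatic ring in this group does not by itself bring the number down to that of compound 1. No measurement is available that would explain this result.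

Compound 4 differs from compound 1 by both a sulfur in place of the oxygen and a chlorine on the ring, so the compounds shown cannot say which of the two goes with the higher number; a benzylsulfanyl group without chlorine, or a 4-chlorobenzyloxy group, would separate them. Also open, going by these compounds, is how a shorter chain such as butyloxy, or an amine on this carbonyl carbon, would compare with hexyloxy.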